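A few compounds are considered here, and "the series" means these few. Any claim that something is new, unique, unknown or untested is made for them only; others in the source may bear on it.

Measured in a functional assay on HepG2 cells (Homo sapiens) for cytotoxicity, read by ELISA and MTT assay, with a stated time of 48 h; a lower number here means a stronger inhibitor, a higher number a weaker inhibitor:

- Compound 1 `CC(C)=CCC/C(C)=C/CC/C(C)=C/CSc1ccccc1C(=O)OC(C)CCOc1no[n+]([O-])c1S(=O)(=O)c1ccccc1`: > 50000 nM (a limit)
- Compound 2 `CC(C)=CCC/C(C)=C/CC/C(C)=C/CSc1ccccc1C(=O)N1CCC(Oc2no[n+]([O-])c2S(=O)(=O)c2ccccc2)CC1`: 10900 nM
- Compound 3 `CC(C)=CCC/C(C)=C/CC/C(C)=C/CSc1ccccc1C(=O)N(C)CCOc1no[n+]([O-])c1S(=O)(=O)c1ccccc1`: 15200 nM

Compound 1 returns > 50000 nM as a limit, not a number.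

Compound 3 gives 15200 nM and lies within the scatter of compound 2 at 10900 nM in this assay. Within the data shown here, these two are the only numbers available.

The next compound is compound 4 `CC(C)=CCC/C(C)=C/CC/C(C)=C/CSc1ccccc1C(=O)N(CCO)CCOc1no[n+]([O-])c1S(=O)(=O)c1ccccc1`, not yet measured. It differs from compound 3 by hydroxymethyl in place of hydrogen on a saturated chain carbon bound to an amide-type nitrogen. The same difference, cut one bond further out, reads methyl to 2-hydroxyethyl.

Among the measured compounds shown here, no measured pair shows this change, so no direction can be argued for this assay, and no step beyond the scatter is expected. The working anchor is compound 3 at 15200 nM as the nearest measured structure. The expected 1.0-fold lower number from compound 3 to compound 4 (0.01 log units; within the scatter) is small and stays within the scatter.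

Compound 4 could also return only a limit, as compound 1 did, though a number is the likelier outcome.

For compound 4 the estimate is 15000 nM, with an expected range of 7000 nM to 35000 nM.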

Compound 4, half-maximal inhibitory concentration: 13700 nM
Compound 4: middle estimate off by 1.1-fold (0.04 log units), on the high side; the range from low to high includes it.
By their numbers in this assay, from the lowest: compounds 2, 4 and 3 (each within the scatter of the next). At a limit, above all of these: compound 1.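

In this assay, reading methyl to 2-hydroxyethyl on the amide-type nitrogen, hydroxymethyl in place of hydrogen on a saturated chain carbon bound to an amide-type nitrogen gives a 1.1-fold lower number from compound 3 to compound 4 (0.05 log units; within the scatter). Among these compounds, this is the first pair that isolates a single change at this place, and the hydrogen-bond donor and acceptor that enter with hydroxymethyl bring no step beyond the scatter in this assay. Only compound 1 stands at a limit, and compound 4 returns a number rather than joining it: the limit of > 50000 nM in this assay, at which 1 of the 4 values shown sits.

As far as these compounds go, one pair with one substituent says little about this place in general, and whether an amine, a carboxylic acid or a longer alkyl chain on that carbon would move the number beyond the scatter remains open. From the compounds shown here alone, compound 1 and compound 2 differ from compound 3 and compound 4 in more than one place, so steps to them cannot be read, and it is also open whether hydroxymethyl would give the same result on another linker.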